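The source may hold more compounds than are shown below. What is called first, only, known or untested is meant among the compounds shown, and "the series" means these compounds.

Measured so far:
- Compound 1, `CCCNC(=O)C1C(C(=O)O)[C@@H]2CC[C@H]1O2`: 10000 nM
- Compound 2, `Cc1cc(C)c(NC(=O)C2C(C(=O)O)[C@@H]3CC[C@H]2O3)c(C)c1`: 10000 nM
- Compound 3, `O=C(O)c1ccc(NC(=O)C2C(C(=O)O)[C@@H]3CC[C@H]2O3)cc1Cl`: 10000 nM

In an ADME assay on HT-29 cells (Homo sapiens) for cytotoxicity, read by MTT assay, with a stated time of 72 h (on this read-out higher numbers stand for weaker inhibition of growth and lower numbers for stronger inhibition of growth), compound 1 gives 10000 nM. Compound 2 gives 10000 nM and compound 3 gives 10000 nM, so all three stand level, within the scatter of one another; compound 1 is neither stronger nor weaker than either of them on these numbers. The unmeasured compound 4, `O=C(O)CCCNC(=O)C1C(C(=O)O)[C@@H]2CC[C@H]1O2`, differs from compound 1 by carboxy in place of hydrogen on a saturated chain carbon, three bonds along the chain from an amide-type nitrogen. Among the measured compounds shown here, no step between measured compounds is recorded, so there is nothing here to show that such a change moves the read-out. Compound 4 is therefore expected to stay level with compound 1, a step of no change at the digits printed from compound 1 to compound 4 (within the scatter), which is none beyond the scatter. The estimate for compound 4 is 10000 nM, in the range 5000 nM to 20000 nM.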

Compound 4, concentration for 50% growth inhibition: 10000 nM
Beside the measured number, compound 4's estimate shows no gap at the digits printed; measured number inside the range.
By their numbers in this assay, from the lowest: compounds 1, 2, 3 and 4 (each within the scatter of the next).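

In this assay, carboxy in place of hydrogen on a saturated chain carbon, three bonds along the chain from an amide-type nitrogen, gives no change at the digits printed from compound 1 to compound 4 (within the scatter) and so does not separate the two compounds. Among the compounds shown here, this is the first step that can be read at a single place, and it shows that going from propyl to 3-carboxypropyl leaves the read-out unmoved. Nothing measured here bears on why this is so. Going by these compounds, whether an amine or a longer chain at this position would shift the read-out remains open.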